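A Hydroxy Group Enters the Side Chain of Compound 3

The source may report more compounds than this note shows. Statements on the series, on what has been measured and on what is new or still open speak of the compounds shown alone.

Three compounds sharing one core were measured in a functional assay on a cell-free system (plasma) for inhibition of platelet-activating factor acetylhydrolase (Homo sapiens), tested at 100 nM; on this read-out higher numbers stand for more inhibition at the one concentration tested (going by the name of the read-out) and lower numbers for less inhibition. Compound 1 `CCCCCCCCN(C)C(=O)Cn1cc(Cc2cnc(OC)nc2)c(=O)nc1SCc1ccc(F)cc1` gives 39%, compound 2 `CCCCCCCCN(C)C(=O)Cn1cc(Cc2cnc(O)nc2)c(=O)nc1SCc1ccc(F)cc1` gives 66%, and compound 3 `CCCCCCCCN(C)C(=O)Cn1cc(Cc2cnc(=O)n(CC)c2)c(=O)nc1SCc1ccc(F)cc1` gives 48%. Compound 3 stands second highest of the three: its nearest neighbour is compound 1, within the scatter, and its furthest is compound 2, beyond the scatter. The measured steps were a number 27 percentage points higher from compound 1 to compound 2 (beyond the scatter) and a number 18 percentage points lower from compound 2 to compound 3 (beyond the scatter), while a number 9 percentage points higher from compound 1 to compound 3 (within the scatter).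

Compound 4 `CCCCCCCCN(C)C(=O)Cn1cc(Cc2cnc(=O)n(CCO)c2)c(=O)nc1SCc1ccc(F)cc1` differs from compound 3 by hydroxy in place of hydrogen on a saturated chain carbon, two bonds along the chain from an aromatic nitrogen. Going by the values given here, no measured step alters this place on the chain; the steps seen so far change the ring itself rather than its chain. The analyst therefore expects only a small step, a number 4 percentage points higher from compound 3 to compound 4 (within the scatter), within the scatter. The estimate for compound 4 in this assay is 52%, with a range from 38% to 68%.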

Compound 4, a percentage reported as inhibition, at one concentration (the size of the read-out at that concentration, not a potency): 59%
The estimate for compound 4 lay 7 percentage points below the measured number; measured number inside the range.
By their numbers in this assay, from the lowest: compounds 1 and 3 (each within the scatter of the next); then compounds 4 and 2 (each within the scatter of the next).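

In this assay, this is the first change shown on the chain itself, and ethyl to 2-hydroxyethyl registers as a number 11 percentage points higher from compound 3 to compound 4 (beyond the scatter). Compound 3 stood within the scatter of compound 1, whereas the hydroxy brings a number 20 percentage points higher from compound 1 to compound 4 (beyond the scatter) and leaves a number 7 percentage points lower from compound 2 to compound 4 (within the scatter). No measurement here accounts for the step. On these data alone, whether an amine, a carboxylic acid or a methoxy group in place of this hydroxy would give the same result stays open, as does the effect of a longer chain such as 3-hydroxypropyl.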